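The source may hold more compounds than are shown below. What is called first, only, known or untested is meant among the compounds shown, and "the series" means these compounds.

Measured compounds:
- compound 1, `COc1ccc(-c2[nH]c3ccccc3c2/C=C(\C#N)S(=O)(=O)c2ccccc2)cc1`, 554 nM
- compound 3, `N#C/C(=C\c1c(-c2ccccc2)[nH]c2ccccc12)S(=O)(=O)c1ccccc1`, 1100 nM
- compound 2, `O=C(/C(=C\c1c(-c2ccccc2)[nH]c2ccccc12)S(=O)(=O)c1ccccc1)c1ccccc1`, "not determined" (no result reported)

In a functional assay on HCT-15 cells (Homo sapiens) for inhibition, read by sulforhodamine B assay, with a stated time of 48 h (on this read-out lower numbers stand for stronger inhibition of growth and higher numbers for weaker inhibition of growth), compound 1 gives 554 nM. In this assay compound 3 gives 1100 nM. For the measured compounds named here, the one step between them, a 2.0-fold higher number from compound 1 to compound 3 (0.30 log units; within the scatter), is within the scatter, so compound 3 and compound 1 are not separated on this read-out. Compound 2, which carries a benzoyl on the double-bonded chain carbon, has no number in this assay.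

Compound 4, `N#C/C(=C\c1c(-c2ccccc2)[nH]c2ccccc12)C(=O)c1ccccc1`, is not yet measured. Its change from compound 3 is benzoyl in place of phenylsulfonyl on a double-bonded chain carbon bound to a double-bonded chain carbon and a triple-bonded carbon. No measured step covers this exchange: the only step shown, a 2.0-fold higher number from compound 1 to compound 3 (0.30 log units; within the scatter), concerns the methoxy on an aromatic carbon and says nothing about the group on the chain carbon, and compound 2, the nearest comparison for a benzoyl in this position, reports no result. The expectation for compound 4 therefore rests on the shared core alone, and the step of a 1.4-fold higher number from compound 3 to compound 4 (0.13 log units; within the scatter) is expected to stay near the scatter, with no direction claimed. Compound 4 is estimated at 1500 nM, with a range from 400 nM to 6000 nM, the wide range reflecting the absence of any measured step bearing on this exchange.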

Compound 4, concentration for 50% growth inhibition: 3500 nM
Compound 4: middle estimate off by 2.3-fold (0.37 log units), on the low side; measured number inside the range.
By their numbers in this assay, from the lowest: compounds 1 and 3 (each within the scatter of the next); then compound 4.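

In this assay, for the compounds shown here, the step of a 3.2-fold higher number from compound 3 to compound 4 (0.50 log units; beyond the scatter) is the first to lie beyond the scatter, and it is modest in size. The group on a double-bonded chain carbon bound to a double-bonded chain carbon and a triple-bonded carbon therefore separates two compounds on this read-out, which the methoxy exchange linking compound 1 and compound 3 did not do, with phenylsulfonyl carrying the lower number of the pair and benzoyl the higher. No measurement at hand gives a reason for this difference.

On these data alone, this place rests on a single pair, so it remains open whether phenylsulfonyl and benzoyl would separate in the same order with a methoxy on the aromatic carbon, as in compound 1, and compound 2 offers no number to test the exchange of the nitrile. Also open, as far as these compounds go, is how a methyl ester or a primary amide would read at this place, and whether the number would then fall nearer that of compound 3 or that of compound 4.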